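Notes on the butylamino aminopyrimidine series at the eighth Toll-like receptor

The source may report more compounds than this note shows. Statements on the series, on what has been measured and on what is new or still open speak of the compounds shown alone.

Measured so far:
compound 1 `CCCCNc1nc(N)nc(C)c1CCCCO`: 1310 nM
compound 2 `CCCCNc1nc(N)nc(C)c1CCc1ccccc1`: 1190 nM
compound 3 `CCCCNc1nc(N)nc(C)c1CCCN1CCCC1`: 110 nM

In an assay on HEK293 cells for agonist activity at Toll-like receptor 8 (Homo sapiens), read by spectrophotometry (a lower number here means that less compound is needed, a higher number that more compound is needed for the effect), compound 1 gives the highest number of the three. Its nearest neighbour is compound 2, a 1.1-fold lower number from compound 1 to compound 2 (0.04 log units; within the scatter); its furthest is compound 3, a 12-fold lower number from compound 1 to compound 3 (1.08 log units; beyond the scatter).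

Compound 4 `CCCCNc1nc(N)nc(C)c1C#C[Si](C)(C)C` differs from compound 1 in one place: a group of 6 heavy atoms (5 carbon, 1 silicon; no ring) in place of a group of 5 heavy atoms (4 carbon, 1 oxygen; no ring), on an aromatic carbon. The step from compound 1 to compound 2 bears on this change most directly, as it also removes the oxygen-bearing chain for an uncharged group without donors or acceptors, and it stayed within the scatter. The large gain from compound 1 to compound 3 came with a pyrrolidin-1-yl group, which compound 4 does not carry, so that step gives no support for an improvement here. In this assay no step beyond the scatter is therefore expected for compound 4, a 1.1-fold higher number from compound 1 to compound 4 (0.06 log units; within the scatter). Compound 4 is estimated at 1500 nM, between 500 nM and 5000 nM.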

Compound 4, half-maximal effective concentration: 9240 nM
The estimate for compound 4 lay 6.2-fold (0.79 log units) below the measured number, and the stated range ends below it.
By their numbers in this assay, from the lowest: compound 3; then compounds 2 and 1 (each within the scatter of the next); then compound 4.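

In this assay, this aromatic carbon does not tolerate every uncharged group equally: putting the silicon-bearing group with its triple bond in place of 4-hydroxybutyl gives a 7.1-fold higher number from compound 1 to compound 4 (0.85 log units; beyond the scatter). Compound 2 also carries no hydroxyl, yet it stays within the scatter of compound 1, so loss of the hydroxyl alone does not go with the rise. Nothing available accounts for this rise.

The compounds shown leave open whether the triple bond or the trimethylsilyl group goes with the higher number. Also open, from the compounds shown here alone, is whether an amine other than pyrrolidine, such as a primary aminobutyl chain, would match compound 3.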